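Oxime ether chain length in the imidazoline aniline series

The source may report more compounds than this note shows. Statements on the series, on what has been measured and on what is new or still open speak of the compounds shown alone.

Measured so far in a functional assay for activation of Alpha-1A adrenergic receptor (Homo sapiens), read by calcium flux; a higher number here means that more compound is needed for the effect, a lower number that less compound is needed:
Compound 1 `Cc1ccsc1-c1ccccc1NCC1=NCCN1` gives 0.851 nM.
Compound 2 `CO/N=C(\C)c1ccccc1NCC1=NCCN1` gives 20.9 nM.

Within the data shown here, compound 2 holds the higher of the two numbers in this assay; the only measured step, a 25-fold higher number from compound 1 to compound 2 (1.39 log units; beyond the scatter), separates it from the other compound, and that step is large.

Compound 3 `CC/C(=N\OC)c1ccccc1NCC1=NCCN1` is the next member. It differs from compound 2 by methyl in place of hydrogen on a saturated chain carbon bound to a carbon with a double bond to nitrogen. Among the measured compounds shown here, no measured step bears on this kind of change: the single step measured swaps an entire aromatic group for an open chain, whereas here one hydrogen on the saturated chain carbon becomes a methyl. It gives no guide to direction, so the expectation rests on the small size of the change alone. A shift within the scatter, in either direction, is expected. Compound 3 is estimated at 25 nM, with a range from 8 nM to 80 nM. That estimate means an expected step of a 1.2-fold higher number from compound 2 to compound 3 (0.08 log units; within the scatter), not beyond the scatter.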

Compound 3, half-maximal effective concentration: 3.31 nM
The estimate for compound 3 lay 7.6-fold (0.88 log units) above the measured number; the whole stated range lies above it.
By their numbers in this assay, from the lowest: compound 1; then compound 3; then compound 2.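

In this assay the methyl to ethyl change, on a saturated chain carbon bound to a carbon with a double bond to nitrogen, is not silent: a 6.3-fold lower number from compound 2 to compound 3 (0.80 log units; beyond the scatter) shows that this position responds to a single added methyl. The open chain also stands closer to the aromatic group of compound 1 after this change, with a 3.9-fold higher number from compound 1 to compound 3 (0.59 log units; beyond the scatter) in place of the earlier 25-fold higher number from compound 1 to compound 2 (1.39 log units; beyond the scatter) so the large step seen with compound 2 does not follow from the loss of the ring alone. Nothing at hand accounts for the shift at this position.

From the compounds shown here alone, two compounds with open chains fix no trend, so whether a propyl or isopropyl group at this place would lower the number further remains open. Also open, going by these compounds, is how an ethyl group in place of the methyl on the oxime oxygen would read.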